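The compounds below may be only part of what the source reports. "The series", "measured", "known", "first", "only" and "open" are said of these compounds alone.

Going by the values given here, in an assay on a protein complex (Cavia porcellus) with sulfonylurea receptors; K-ATP channels (Homo sapiens) as the target (on this read-out lower numbers stand for stronger inhibition and higher numbers for weaker inhibition), compound 3 `CCN(CC)S(=O)(=O)c1ccc(NC(=O)C(C)(O)C(F)(F)F)cc1` gives 810 nM, the only number among the three values shown. Compound 1 `CC(C)CN(CC(C)C)S(=O)(=O)c1ccc(NC(=O)C(C)(O)C(F)(F)F)cc1` reaches only the limit > 30000 nM. Compound 2 `CC(O)(C(=O)Nc1ccc(S(=O)(=O)N2CCNCC2)cc1)C(F)(F)F` likewise gives only the limit > 30000 nM. The steps of an at least 37-fold lower number from compound 1 to compound 3 (1.56 log units; beyond the scatter) and an at least 37-fold lower number from compound 2 to compound 3 (1.56 log units; beyond the scatter) are both large, and the step that the two limits leave unreadable from compound 1 to compound 2 cannot be read because both values sit at the limit of > 30000 nM in this assay, at which 2 of the 3 values shown sit. Compound 4 `CC(O)(C(=O)Nc1ccc(S(=O)(=O)N2CCOCC2)cc1)C(F)(F)F` differs from compound 3 by morpholin-4-yl in place of diethylamino on a sulfonyl sulfur. Among the compounds with values here, both measured steps towards compound 3 point the same way: the diethylamino group gives the only number, while diisobutylamino and piperazin-1-yl give only limits. The ring entering here is expected to weaken binding in this assay, with a 3.7-fold higher number from compound 3 to compound 4 (0.57 log units; beyond the scatter). Compound 4 is therefore estimated at 3000 nM, between 800 nM and 30000 nM.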

Compound 4, half-maximal inhibitory concentration: 5850 nM
Beside the measured number, compound 4's estimate is 2.0-fold (0.29 log units) below it; low and high end bracket the measured number.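

With morpholin-4-yl on the sulfonyl sulfur, this assay gives a second true number rather than a limit, so this place can carry a ring, although diethylamino remains better, with a 7.2-fold higher number from compound 3 to compound 4 (0.86 log units; beyond the scatter). Having a ring is not enough on its own, as piperazin-1-yl goes against any such rule, with an at least 5.1-fold lower number from compound 2 to compound 4 (0.70 log units; beyond the scatter). The step for the acyclic group is similar, with an at least 5.1-fold lower number from compound 1 to compound 4 (0.70 log units; beyond the scatter), and the true size of both steps stays unknown, as each starts from a limit: the limit of > 30000 nM in this assay, at which 2 of the 4 values shown sit.

From the compounds shown here alone, it remains open how dimethylamino or the smaller pyrrolidin-1-yl ring would behave at this place.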